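This account rests on a few compounds, and the source may have more. Where it says the series, first, only, none or still open, it means among the compounds named here.

Measured in a functional assay on HepG2 cells (Homo sapiens) for antiproliferative activity, read by MTT assay, with a stated time of 48 h; on this read-out lower numbers stand for stronger inhibition and higher numbers for weaker inhibition:
compound 1 `COc1ccccc1CNc1ccc2ncnc(Nc3cccc(Br)c3)c2c1` gives 8820 nM
compound 2 `Clc1ccccc1CNc1ccc2ncnc(Nc3cccc(Br)c3)c2c1` gives 1820 nM
compound 3 `COc1ccccc1CNc1ccc2ncnc(Nc3cccc(Cl)c3)c2c1` gives 9850 nM

Compound 3 stands level with compound 1, a 1.1-fold higher number from compound 1 to compound 3 (0.05 log units; within the scatter), and both numbers lie above that of compound 2. Next is compound 4 `COc1ccc(CNc2ccc3ncnc(Nc4cccc(Cl)c4)c3c2)cc1`, with 4-methoxyphenyl in place of 2-methoxyphenyl on a saturated chain carbon bound to a nitrogen on an aromatic ring. Going by the values given here, no measured step moves the methoxy group. The closest evidence is chloro in place of methoxy, a 4.8-fold lower number from compound 1 to compound 2 (0.69 log units; beyond the scatter), a modest shift at that ring. Chloro in place of bromo, a 1.1-fold higher number from compound 1 to compound 3 (0.05 log units; within the scatter), suggests that compound 1 can inform this comparison. A small move toward a lower number is therefore expected, possibly none beyond the scatter. The estimated step in this assay is a 1.5-fold lower number from compound 3 to compound 4 (0.18 log units; within the scatter). For compound 4 the estimated value is 6500 nM, with an expected range from 2500 nM to 16000 nM.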

Compound 4, half-maximal inhibitory concentration: 5260 nM
Beside the measured number, compound 4's estimate is 1.2-fold (0.09 log units) above it; measured number inside the range.
By their numbers in this assay, from the lowest: compound 2; then compounds 4, 1 and 3 (each within the scatter of the next).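

In this assay the methoxy group can now be read at two ring placements: 4-methoxyphenyl in place of 2-methoxyphenyl gives a 1.9-fold lower number from compound 3 to compound 4 (0.27 log units; within the scatter) on the saturated chain carbon bound to a nitrogen on an aromatic ring. Moving the methoxy group therefore stays within the scatter, whereas replacing it with chloro gave a 4.8-fold lower number from compound 1 to compound 2 (0.69 log units; beyond the scatter) and lay beyond it. No measurement in hand accounts for this result.

Still open, from the compounds shown here alone, is whether 4-methoxyphenyl reads the same with bromo in place of chloro. Also open, going by these compounds, is whether an amine or a carboxylic acid on this ring would shift the number as chloro did.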